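Compound 3: swapping chloro for amino

The source may report more compounds than this note shows. Statements on the series, on what has been measured and on what is new or still open speak of the compounds shown alone.

Measured in a functional assay on U-251 cells (Homo sapiens) for antiproliferative activity, read by MTT assay, with a stated time of 48 h; a lower number here means a stronger inhibitor, a higher number a weaker inhibitor:
Compound 1 `COc1cc(-c2cccc3nc(-c4ccccc4)oc23)cc(OC)c1OC`: 3500 nM
Compound 2 `COc1cc(-c2cccc3nc(-c4ccc(Cl)cc4)oc23)cc(OC)c1OC`: 1600 nM
Not yet measured: compound 3 `COc1cc(-c2cccc3nc(-c4ccc(N)cc4)oc23)cc(OC)c1OC`

Of the two measured compounds, compound 2 has the lower number, 1600 nM, which makes it the stronger inhibitor of the pair. Within the data shown here, the only measured step is a 2.2-fold lower number from compound 1 to compound 2 (0.34 log units; beyond the scatter). That step put chloro in place of hydrogen on an aromatic carbon, and it is modest in size.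

Compound 3 keeps the shared core and changes one group, a 4-chlorophenyl to 4-aminophenyl swap: amino in place of chloro on an aromatic carbon. This places amino in place of chloro on an aromatic carbon, para to a large group.

Among the measured compounds shown here, no compound carrying amino has been measured yet, so the modest step to compound 2 is the only guide. A similarly small move is expected, most likely back towards a higher number in this assay, and it may not clearly exceed the scatter. The estimated move is a 1.6-fold higher number from compound 2 to compound 3 (0.19 log units; within the scatter). The estimate for compound 3 is 2500 nM, with an expected range from 800 nM to 7000 nM.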

Compound 3, half-maximal inhibitory concentration: 1040 nM
For compound 3 the middle estimate is 2.4-fold (0.38 log units) above the measured one; the range from low to high includes it.
By their numbers in this assay, from the lowest: compounds 3 and 2 (each within the scatter of the next); then compound 1.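

In this assay, the step of a 1.5-fold lower number from compound 2 to compound 3 (0.19 log units; within the scatter) is within the scatter, so at this position, para to a large group, chloro and amino cannot be told apart, even though amino counts a hydrogen-bond donor and a hydrogen-bond acceptor and chloro counts neither. The step of a 3.4-fold lower number from compound 1 to compound 3 (0.53 log units; beyond the scatter) lies beyond the scatter and adds a second group to chloro: among these three compounds, both substituted versions sit at a lower number than the one with hydrogen, and none goes against this, though two groups are a small sample for such a reading. Nothing measured here explains why two such different groups land so close together.

On these data alone, it remains open whether a small group such as methyl or hydroxyl would join chloro and amino or fall back towards the number of compound 1, and whether a dimethylamino group, which keeps the nitrogen but has no hydrogens on it, would behave like amino. The compounds shown also leave open whether amino would give a similar result at any other carbon of the same ring.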